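Sulfonamide Nitrofuran Amides: From Chloropiperidine to Phenyl

The source may report more compounds than this note shows. Statements on the series, on what has been measured and on what is new or still open speak of the compounds shown alone.

Two analogues of a nitrofuran amide are available in an ADME assay on IMR-90 cells (Homo sapiens) for cytotoxicity, read by CellTiter-Blue, with a stated time of 46 h; a higher number here means that more compound is needed for the effect, a lower number that less compound is needed. Compound 1 `O=C(Nc1ccc(S(=O)(=O)N2CCC3(CCCCC3)CC2)cc1)c1ccc([N+](=O)[O-])o1` reaches only a limit of the assay, giving > 25000 nM. Compound 2 `O=C(Nc1ccc(S(=O)(=O)N2CCC(Cl)CC2)cc1)c1ccc([N+](=O)[O-])o1` likewise stops at a limit, with > 25000 nM. For the measured compounds named here, compound 2 therefore sits at the limit of > 25000 nM in this assay, at which 2 of the 2 values shown sit, and no measured step exists between the two. Compound 3 `O=C(Nc1ccc(S(=O)(=O)c2ccccc2)cc1)c1ccc([N+](=O)[O-])o1` differs from compound 2 by phenyl in place of 4-chloropiperidin-1-yl on a sulfonyl sulfur. With both measured values resting at the same limit, no step beyond the scatter is expected in this assay. Compound 3 is estimated at 25000 nM, between 10000 nM and 60000 nM, which corresponds to an expected a number no higher from compound 2 to compound 3 (the limit leaves the size open).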

Compound 3, half-maximal effective concentration: > 25000 nM
Compound 3 was reported as a limit; the forecaster's own chance of this, stated with the estimate: 75%; the middle value lies on the limit itself.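

In this assay, for the compounds shown here, compound 2 and compound 3 both rest at a limit, so no step between them can be read. The compounds shown leave open where their true values lie, and whether phenyl and 4-chloropiperidin-1-yl differ at all.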